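The source may report more compounds than this note shows. Statements on the series, on what has been measured and on what is new or still open speak of the compounds shown alone.

Measured in a functional assay on NCI-H460 cells (Homo sapiens) for cytotoxicity, read by MTT assay, with a stated time of 48 h; on this read-out lower numbers stand for stronger inhibition and higher numbers for weaker inhibition:
- Compound 1 `COc1ccc2[nH]c(-c3ccccc3F)cc(=O)c2c1OC`: > 20000 nM, a limit of the assay
- Compound 2 `COc1cc2c(=O)cc(-c3ccccc3F)[nH]c2cc1O`: 4400 nM
- Compound 3 `COc1cc2c(=O)cc(-c3cccc(F)c3)[nH]c2cc1O`: 4800 nM

Compound 3 stands level with compound 2, within the scatter. Compound 1 gives only a limit.

Compound 4 `COc1cc2c(=O)cc(-c3ccc(F)cc3)[nH]c2cc1O` differs from compound 3 in one place: 4-fluorophenyl in place of 3-fluorophenyl on an aromatic carbon. It carries 4-fluorophenyl in place of 3-fluorophenyl on an aromatic carbon, next to the ring nitrogen.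

Among the measured compounds shown here, the one measured step of this kind exchanges 2-fluorophenyl for 3-fluorophenyl, and it is small: a 1.1-fold higher number from compound 2 to compound 3 (0.04 log units; within the scatter). On that single step, no change beyond the scatter is expected in this assay. The expected step is a 1.0-fold lower number from compound 3 to compound 4 (0.02 log units; within the scatter). Compound 4 is estimated at 4600 nM, with an expected range of 2300 nM to 9500 nM.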

Compound 4, half-maximal inhibitory concentration: > 100000 nM
Compound 4: only a limit was reported (the forecaster's own chance of this, stated with the estimate: 5%); middle value at least 21-fold (1.33 log units) from the limit.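

In this assay, the aromatic carbon next to the ring nitrogen proves sensitive to where the fluorine sits on the phenyl ring: 4-fluorophenyl gives an at least 20-fold higher number from compound 3 to compound 4 (1.31 log units; beyond the scatter) and an at least 22-fold higher number from compound 2 to compound 4 (1.35 log units; beyond the scatter). Among the compounds shown here, the 2-fluorophenyl and 3-fluorophenyl groups had stood level, so the earlier compounds gave no sign of this. Compound 4 gives only a limit, and the full size of both steps stays unknown: the limit of > 100000 nM in this assay, at which 1 of the 4 values shown sits.

The compounds shown leave open whether a 4-chlorophenyl or 4-methoxyphenyl group at this place would behave like 4-fluorophenyl, and whether an unsubstituted phenyl would stand level with compound 3.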